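Moving the chlorine on a shared aromatic core

The compounds below may be only part of what the source reports. "The series", "measured", "known", "first", "only" and "open" are said of these compounds alone.

Compound 3 `Oc1cccc(-c2cc(-c3ccc(Cl)cc3)nc(-c3ccsc3)c2)c1` holds the lowest of the three numbers in an ADME assay on HEK293 cells (Homo sapiens) for cytotoxicity, read by CCK-8 assay and cell counting, with a stated time of 2 days (on this read-out higher numbers stand for weaker inhibition and lower numbers for stronger inhibition), though every step to the others lies within the scatter; compound 3 gives 11200 nM. Compound 1 `Oc1cccc(-c2cc(-c3ccc(Cl)cc3)nc(-c3cccs3)c2)c1` gives 11800 nM and compound 2 `Oc1cccc(-c2cc(-c3ccc(Cl)cc3)nc(-c3ccccn3)c2)c1` gives 14000 nM, and the steps of a 1.1-fold lower number from compound 1 to compound 3 (0.02 log units; within the scatter), a 1.3-fold lower number from compound 2 to compound 3 (0.10 log units; within the scatter) and a 1.2-fold higher number from compound 1 to compound 2 (0.07 log units; within the scatter) all stay within the scatter. Compound 4 `Oc1cccc(-c2cc(-c3ccsc3)nc(-c3cccc(Cl)c3)c2)c1` differs from compound 3 by 3-chlorophenyl in place of 4-chlorophenyl on an aromatic carbon. Going by the values given here, none of the measured steps touches the chlorophenyl group: each exchanges a different ring on the shared core, and none moved the number beyond the scatter. Among the compounds with values here, no step therefore bears directly on this change, and no shift beyond the scatter is expected: no change at the digits printed from compound 3 to compound 4 (within the scatter). Compound 4 is estimated to give 11200 nM, within 6000 nM to 22000 nM.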

Compound 4, half-maximal inhibitory concentration: 3180 nM
Compound 4: middle estimate off by 3.5-fold (0.55 log units), on the high side; the whole stated range lies above it.
By their numbers in this assay, from the lowest: compound 4; then compounds 3, 1 and 2 (each within the scatter of the next).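

Across compound 1, compound 2 and compound 3, exchanging one ring left the number within the scatter, but moving the chlorine on the other ring does not: in this assay the result is a 3.5-fold lower number from compound 3 to compound 4 (0.55 log units; beyond the scatter). With the same atoms joined differently, this group next to the ring nitrogen is sensitive to where its chlorine sits. The evidence available offers no explanation for this shift.

As far as these compounds go, it remains open whether the shift persists with the thiophen-2-yl or pyridin-2-yl group in place of thiophen-3-yl. Also open, from the compounds shown here alone, is what 2-chlorophenyl, or an amine in place of the chlorine, would give.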